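A few compounds are considered here, and "the series" means these few. Any claim that something is new, unique, unknown or untested is made for them only; others in the source may bear on it.

Compound 1 `Cc1ccc2nc(C(=O)Nc3c(F)cc(-c4cccc(F)c4)cc3F)c(C)c(O)c2c1` has been tested in a functional assay on A-375 cells (Homo sapiens) for antiproliferative activity, read by MTT assay, with a stated time of 24 h, tested at 0.01 ug/mL (a lower number here means a weaker effect, a higher number a stronger effect of the compound at the concentration tested), where compound 1 gives 0.1%. Compound 2 `Cc1c(C(=O)Nc2c(F)cc(-c3cccc(F)c3)cc2F)nc2ccc(OC(F)(F)F)cc2c1O` differs from compound 1 in one place, and in this assay compound 2 gives -0.68%. Of these two numbers, compound 1 holds the higher one, yet the step of a number 0.8 percentage points lower from compound 1 to compound 2 (within the scatter) is too small to set the two compounds apart. Compound 3 `Cc1ccc2nc(C(=O)Nc3c(F)cc(-c4cccc(F)c4)cc3F)c(C)c(C(=O)O)c2c1` has not yet been measured. It differs from compound 1 as follows: carboxy in place of hydroxy on an aromatic carbon. Among the measured compounds shown here, no measured step involves this change; the one step that exists concerns a different group and stays within the scatter. Both measured values sit near zero, so a sizeable step in this assay is not expected in either direction. Compound 3 is therefore estimated at 0%, between -10% and 10%, a step of a number 0.1 percentage points lower from compound 1 to compound 3 (within the scatter) that is expected to stay within the scatter.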

Compound 3, a percentage reported as inhibition, at one concentration (the size of the read-out at that concentration, not a potency): -1.05%
Beside the measured number, compound 3's estimate is 1.1 percentage points above it; low and high end bracket the measured number.
By their numbers in this assay, from the lowest: compounds 3, 2 and 1 (each within the scatter of the next).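

In this assay, carboxy in place of hydroxy on the aromatic carbon opposite the ring nitrogen gives a number 1.2 percentage points lower from compound 1 to compound 3 (within the scatter), so this change cannot set the two compounds apart. Among the compounds shown here, this is the first view of this position, and the larger group, with three heavy atoms in place of one, still leaves the read-out near zero, as it was for the earlier change elsewhere on the core. Nothing available here bears on why this result came out as it did.

The compounds shown leave open whether an amine or a methoxy group on this same carbon would give a step beyond the scatter. They also leave open whether compound 1 and compound 3 would separate at a higher concentration, where the read-out is no longer close to zero.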